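Pyridin-3-yl for thiophen-2-yl: series notes

A few compounds are considered here, and "the series" means these few. Any claim that something is new, unique, unknown or untested is made for them only; others in the source may bear on it.

compound 1 `O=C(CCCCCC(=O)Nc1nnc(-c2cccnc2)s1)NO` – 54400 nM
compound 2 `O=C(CCCCCCC(=O)Nc1nnc(-c2cccs2)s1)NO` – 3600 nM

In a functional assay on PC-3 cells (Homo sapiens) for antiproliferative activity, read by MTT assay, with a stated time of 48 h (on this read-out higher numbers stand for weaker inhibition and lower numbers for stronger inhibition), compound 2 gives 3600 nM and holds the lower of the two numbers. Compound 1 gives 54400 nM in the same test. The gap between these two numbers lies beyond the scatter. Compound 3 `O=C(CCCCCCC(=O)Nc1nnc(-c2cccnc2)s1)NO` is still unmeasured and carries pyridin-3-yl in place of thiophen-2-yl on an aromatic carbon. Among the measured compounds shown here, no measured pair isolates this exchange. Compound 1, which also bears pyridin-3-yl, reads 54400 nM, so a rise in the number is expected. The expected change is modest (a 2.5-fold higher number from compound 2 to compound 3 (0.40 log units; beyond the scatter)) and in the direction of weaker inhibition. For compound 3 the estimated value is 9000 nM, within an expected range of 2500 nM to 35000 nM in this assay.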

Compound 3, half-maximal inhibitory concentration: 7980 nM
Compound 3: the middle estimate sits 1.1-fold (0.05 log units) above what was measured, within the range that was stated.
By their numbers in this assay, from the lowest: compound 2; then compound 3; then compound 1.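

Among the compounds shown here, with the chain held fixed, pyridin-3-yl in place of thiophen-2-yl on the aromatic carbon gives a 2.2-fold higher number from compound 2 to compound 3 (0.35 log units; beyond the scatter) in this assay, the first isolated reading of this exchange. With pyridin-3-yl held fixed, (hydroxycarbamoyl)methyl in place of hydroxycarbamoyl on the saturated chain carbon gives a 6.8-fold lower number from compound 1 to compound 3 (0.83 log units; beyond the scatter), so the chain end also moves the number. No data at hand explain either step. Open, on these data alone, is whether the chain step carries over to the thiophen-2-yl compounds, and how a still longer chain reads. Also open, as far as these compounds go, is how a phenyl or aminopyridinyl group reads at this aromatic carbon.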